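The source may hold more compounds than are shown below. What is called first, only, known or untested is meant among the compounds shown, and "the series" means these compounds.

Working notes on the series. The shared core carries two benzyloxy groups and is tied through a short chain to a pyrimidine-type base; the compounds differ in that chain and in the base. Compound 1 `Nc1ncn(CCC2(N)OC(=O)C(OCc3ccccc3)=C2OCc2ccccc2)c(=O)n1` is measured in a functional assay on HepG2 cells (Homo sapiens) for inhibition, read by MTT assay, with a stated time of 72 h (a lower number here means a stronger inhibitor, a higher number a weaker inhibitor), and in this assay compound 1 gives only a limit, > 100000 nM, so no number is known for it. It sits at the limit of > 100000 nM in this assay, at which 1 of the 3 values shown sits, the weak end of what has been seen so far. Compound 2 `Nc1ncn(C/C=C2\OC(=O)C(OCc3ccccc3)=C2OCc2ccccc2)c(=O)n1` in this assay gives 2720 nM. Compound 3 `Nc1ccn(C[C@H](O)[C@H]2OC(=O)C(OCc3ccccc3)=C2OCc2ccccc2)c(=O)n1` in this assay gives 44300 nM. No pair among these three differs in only one place, so no single step has been measured.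

Compound 4 `NC1(CCn2ccc(=O)[nH]c2=O)OC(=O)C(OCc2ccccc2)=C1OCc1ccccc1` is not yet measured. It differs from compound 1 by a group of 8 heavy atoms (4 carbon, 2 nitrogen, 2 oxygen; one six-membered aromatic ring with 2 hetero atoms) in place of a group of 8 heavy atoms (3 carbon, 4 nitrogen, 1 oxygen; one six-membered aromatic ring with 3 hetero atoms), on a saturated chain carbon, two bonds along the chain from a saturated ring carbon; the chain and the amino-bearing saturated ring carbon of compound 1 are kept. Because compound 1 is known only as the limit > 100000 nM, the step to compound 4 cannot be sized from a number; the expectation is that compound 4 stays near the limit, with no shift beyond the usual scatter that can be claimed. Compound 4 is expected to give about 120000 nM, within 30000 nM to 500000 nM. The step this implies, a step that the limit leaves unreadable from compound 1 to compound 4, is an estimate, not a measurement.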

Compound 4, half-maximal inhibitory concentration: > 100000 nM
Compound 4 ended at the assay's limit; the forecaster's own chance of this, stated with the estimate: 60%; the middle value lies beyond the limit too.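

Among these compounds, compound 1 and compound 4 each give only a limit in this assay and not a number, so no step between them can be read: the limit of > 100000 nM in this assay, at which 2 of the 4 values shown sit.

Among the compounds shown here, no pair with two readable values differs in only one place, and how far the base and the chain each count on their own stays open.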